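The source may hold more compounds than are shown below. What is called first, only, known or untested is meant among the compounds shown, and "the series" means these compounds.

Compound 1 `CCOC(=O)c1cc(N)c2nc(-c3ccccc3)cnc2c1` and compound 2 `COC(=O)Nc1cc(N)c2nc(-c3ccccc3)cnc2c1` share one core and differ in a single group. In a functional assay on L1210 cells (Mus musculus) (a lower number here means a stronger inhibitor, a higher number a weaker inhibitor), compound 1 gives only the limit > 100000 nM, a boundary of the assay rather than a number. Compound 2 likewise gives only the limit > 100000 nM in this assay, so it stands at the edge of what the assay reports. Going by the values given here, the one measured step, a step that the two limits leave unreadable from compound 1 to compound 2, cannot be sized, because both ends sit at the limit of > 100000 nM in this assay, at which 2 of the 2 values shown sit. Compound 3 `COC(=O)Nc1cc(N)c2nc(-c3ccccc3)c(O)nc2c1` differs from compound 2 by hydroxy in place of hydrogen on an aromatic carbon. Among the compounds with values here, no measured step bears on this change, so the expected step that the limit leaves unreadable from compound 2 to compound 3 is uncertain. Compound 3 is estimated at 150000 nM, between 30000 nM and 1000000 nM.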

Compound 3, half-maximal inhibitory concentration: 750 nM
Beside the measured number, compound 3's estimate is 200-fold (2.30 log units) above it, and the stated range ends above it.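

In this assay, hydroxy in place of hydrogen gives an at least 130-fold lower number from compound 2 to compound 3 (2.12 log units; beyond the scatter), and this is the first readable value among the compounds shown. This aromatic carbon, next to the ring nitrogen and ortho to a phenyl group, is therefore a place where one added group can turn a compound sitting at the assay's limit into a measurable inhibitor. The step is only a minimum, as its starting value is a limit: the limit of > 100000 nM in this assay, at which 2 of the 3 values shown sit.

From the compounds shown here alone, what a methoxy group, an amine or a fluorine would do at this position stays open. Also open, going by these compounds, is whether hydroxy would give a similar gain with the ethoxycarbonyl group of compound 1.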